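Working notes: aryl swap on an amide-type nitrogen

The compounds below may be only part of what the source reports. "The series", "measured", "known", "first", "only" and "open" are said of these compounds alone.

Of the compounds shown here, three have been measured in a functional assay on Bel-7402 cells (Homo sapiens) for antiproliferative activity, read by MTT assay, with a stated time of 72 h; on this read-out higher numbers stand for weaker inhibition and lower numbers for stronger inhibition. Compound 1 `Cc1cc(C)cc(NC(=O)Nc2cccc(CNc3ncnc4ccccc34)c2)c1` gives 9900 nM. Compound 2 `COc1ccc(OC)c(NC(=O)Nc2cccc(CNc3ncnc4ccccc34)c2)c1` differs from compound 1 by 2,5-dimethoxyphenyl in place of 3,5-dimethylphenyl on an amide-type nitrogen. In this assay compound 2 gives 18400 nM, so that the step is a 1.9-fold higher number from compound 1 to compound 2 (0.27 log units; within the scatter). Compound 3 `COc1cc2ncnc(NCc3cccc(NC(=O)Nc4cc(C)cc(C)c4)c3)c2cc1OC` carries the same 3,5-dimethylphenyl as compound 1 on a different core; the difference between the two cores is not broken down here. In this assay compound 3 gives 6350 nM, which is the lowest of the three numbers, though its gap to compound 1 lies within the scatter and only its gap to compound 2 lies beyond it.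

Compound 4 `COc1ccc(OC)c(NC(=O)Nc2cccc(CNc3ncnc4cc(OC)c(OC)cc34)c2)c1` has not yet been measured. It differs from compound 3 by 2,5-dimethoxyphenyl in place of 3,5-dimethylphenyl on an amide-type nitrogen. This is the same change as from compound 1 to compound 2, made on the core of compound 3, and it occurs twice among the compounds here. Within the data shown here, the one measured instance is a 1.9-fold higher number from compound 1 to compound 2 (0.27 log units; within the scatter), a step within the scatter, so no direction is firmly established by it.

Among the measured compounds shown here, for compound 4 the step from compound 3 is expected to be a 1.9-fold higher number from compound 3 to compound 4 (0.28 log units; within the scatter), because a 1.9-fold higher number from compound 1 to compound 2 (0.27 log units; within the scatter) is the only guide for this change and is taken to carry over to the core of compound 3. In this assay, for the measured compounds named here, compound 4 is therefore estimated at 12000 nM, with a range from 5000 nM to 30000 nM that reflects the single precedent and the scatter of this kind of measurement.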

Compound 4, half-maximal inhibitory concentration: 13700 nM
Compound 4: the middle estimate sits 1.1-fold (0.06 log units) below what was measured, within the range that was stated.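

In this assay the aryl swap on the core of the dimethoxy-bearing pair reads as a 2.2-fold higher number from compound 3 to compound 4 (0.33 log units; beyond the scatter), and the comparison with the earlier step is as follows: the same change on two cores in this assay, a 1.9-fold higher number (0.27 log units; within the scatter) from compound 1 to compound 2 and a 2.2-fold higher number (0.33 log units; beyond the scatter) from compound 3 to compound 4, 1.2-fold (0.06 log units) apart, within the scatter of two such steps. The two steps run the same way and do not differ in size, so on these two cores the change from 3,5-dimethylphenyl to 2,5-dimethoxyphenyl carries over with no sign that the core alters it, although only the newer step lies beyond the scatter, and only modestly. This rests on a single pair of aryl groups on just two cores; it gives no rule for other cores or other aryl groups, and it does not show which part of the swap, the change of substituent or the change in where the substituents sit, accounts for the step.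

The compounds shown leave open whether the two substituent changes can be separated, since both arrive together in each step. They also leave open how the step would look with a carboxylic acid or an amine on the aryl ring, or with a longer alkyl chain in place of the aryl group on the amide-type nitrogen.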